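Cyclobutyl for cyclopropylmethyl on the amine nitrogen

The source may hold more compounds than are shown below. What is called first, only, known or untested is meant among the compounds shown, and "the series" means these compounds.

Measured so far in an ADME assay on liver (Homo sapiens) for metabolic stability, read by LC-MS, using microsomes and NADPH (on this read-out higher numbers stand for a more stable compound and lower numbers for a less stable compound), by compound:
- compound 1 `Cc1cc(CN(C2CCC2)C(CC(=O)O)c2ccc(Cl)cc2)ccc1OCCn1c(=O)ccn(C)c1=O` gives 20%
- compound 2 `COc1cc(CN(CC2CC2)C(CC(=O)O)c2ccc(Cl)cc2)ccc1OCCn1c(=O)ccn(C)c1=O` gives 55%

Compound 2 holds the higher of the two numbers, and its gap to compound 1 lies beyond the usual scatter. Not yet measured is compound 3 `COc1cc(CN(C2CCC2)C(CC(=O)O)c2ccc(Cl)cc2)ccc1OCCn1c(=O)ccn(C)c1=O`, which departs from compound 2 by a single exchange: cyclobutyl in place of cyclopropylmethyl on an amine nitrogen. In words, this is cyclobutyl in place of cyclopropylmethyl on an amine nitrogen. For the measured compounds named here, no measured pair isolates one change, so this assay offers no direct precedent for the size of this step. The expected direction is downward, a lean that rests only on compound 1 at 20% and is therefore weak. The expected change is a number 15 percentage points lower from compound 2 to compound 3 (beyond the scatter), a moderate loss with wide uncertainty. For compound 3 the estimate is 40%, with an expected range of 20% to 60% in this read-out.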

Compound 3, percent of the compound remaining: 61%
For compound 3 the middle estimate is 21 percentage points below the measured one; the whole stated range lies below it.
By their numbers in this assay, from the lowest: compound 1; then compounds 2 and 3 (each within the scatter of the next).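

In this assay, cyclobutyl in place of cyclopropylmethyl on an amine nitrogen gives a number 6 percentage points higher from compound 2 to compound 3 (within the scatter), so with methoxy on the aromatic carbon, these two groups cannot be told apart at this position. The large step lies at the other place: methoxy in place of methyl on an aromatic carbon gives a number 41 percentage points higher from compound 1 to compound 3 (beyond the scatter), which ties the low value of compound 1 to its methyl and not to its cyclobutyl, at least within this single pair. Nothing in the data shown explains either result.

Open, on these data alone, is whether the methoxy step holds with cyclopropylmethyl on the amine nitrogen, since only the cyclobutyl pair reads it. Also open, as far as these compounds go, is how ethoxy or chlorine on that aromatic carbon, or cyclopentyl or a longer chain on the amine nitrogen, would read in this assay.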